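The compounds below may be only part of what the source reports. "The series", "measured", "known", "first", "only" and "open" are said of these compounds alone.

Three compounds share one core and differ only in the group attached to an oxygen on a saturated carbon, and all three have been tested in a functional assay with Homo sapiens as the target; on this read-out higher numbers stand for weaker inhibition and lower numbers for stronger inhibition. Compound 1 `CC(C)[C@H](NC(=O)COc1cccc2ccccc12)C(=O)N[C@@H](CC(=O)O)C(=O)COC(=O)c1c(Cl)cccc1Cl` gives 11500 nM. Compound 2 `CC(C)[C@H](NC(=O)COc1cccc2ccccc12)C(=O)N[C@@H](CC(=O)O)C(=O)COc1ccc([N+](=O)[O-])cc1` gives 22800 nM. Compound 3 `CC(C)[C@H](NC(=O)COc1cccc2ccccc12)C(=O)N[C@@H](CC(=O)O)C(=O)COc1cccc(F)c1` gives 12000 nM. The steps among them are small: a 2.0-fold higher number from compound 1 to compound 2 (0.30 log units; within the scatter), a 1.0-fold higher number from compound 1 to compound 3 (0.02 log units; within the scatter) and a 1.9-fold lower number from compound 2 to compound 3 (0.28 log units; within the scatter). Compound 3 therefore sits within the scatter of both companions, so the three values cannot be told apart with confidence, and none of the compounds can be called the stronger or weaker inhibitor.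

Compound 4 `CC(C)[C@H](NC(=O)COc1cccc2ccccc12)C(=O)N[C@@H](CC(=O)O)C(=O)COc1c(F)cc(F)cc1F` has not yet been measured. The change from compound 3 is 2,4,6-trifluorophenyl in place of 3-fluorophenyl on an oxygen on a saturated carbon. For the measured compounds named here, the two earlier swaps at the same place, the step from compound 1 to compound 3 and the step from compound 2 to compound 3, each stayed within the scatter, and they are the only evidence that bears on this position. The expectation for compound 4 in this assay is therefore a step of no real size, no change at the digits printed from compound 3 to compound 4 (within the scatter), because a 1.9-fold lower number from compound 2 to compound 3 (0.28 log units; within the scatter) shows that the exchange of one group for another at this oxygen has so far left the value essentially unchanged. Compound 4 is estimated at 12000 nM, with a likely range from 6000 nM to 25000 nM.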

Compound 4, half-maximal inhibitory concentration: 14900 nM
Beside the measured number, compound 4's estimate is 1.2-fold (0.09 log units) below it; the range from low to high includes it.
By their numbers in this assay, from the lowest: compounds 1, 3, 4 and 2 (each within the scatter of the next).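

In this assay the exchange of 3-fluorophenyl for 2,4,6-trifluorophenyl on this oxygen gives a 1.2-fold higher number from compound 3 to compound 4 (0.09 log units; within the scatter) and so extends the earlier picture to a change in how many fluorines the phenyl ring carries, which the first three compounds did not cover. The other two comparisons read the same way: there is a 1.5-fold lower number from compound 2 to compound 4 (0.18 log units; within the scatter) and there is a 1.3-fold higher number from compound 1 to compound 4 (0.11 log units; within the scatter) so the 2,4,6-trifluorophenyl group cannot be told apart from the 4-nitrophenyl group or from the (2,6-dichlorophenyl)carbonyl group. Every pair among these four compounds now lies within the scatter, so the position has given the same reading with a fluorinated phenyl, a nitro-bearing phenyl and a ring joined through a carbonyl.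

Nothing available here offers an explanation for this flat result. Still open, from the compounds shown here alone, is whether a group of another kind at this oxygen, such as a phenyl ring bearing an amine or a carboxylic acid, or a longer chain in place of the ring, would move the value beyond the scatter.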